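The compounds below may be only part of what the source reports. "The series", "measured", "known", "first", "only" and "open" are said of these compounds alone.

Compound 1 is `Cc1cccc(C)c1NC(=O)CSc1snnc1-c1ccc(Br)cc1Br`. In an ADME assay on MT4 cells (Homo sapiens) for cytotoxicity, read by MTT assay, with a stated time of 5 days (on this read-out lower numbers stand for higher toxicity in this test and higher numbers for lower toxicity in this test), compound 1 gives >= 198000 nM, which is a limit of the assay rather than a number.
Compound 2 is `O=C(CSc1snnc1-c1ccc(Br)cc1Br)Nc1ccccc1Cl`. In this assay compound 2 gives > 240000 nM, also a limit of the assay.
Compound 3 is `Cc1ccccc1NC(=O)CSc1snnc1-c1ccc(Br)cc1Br`. In this assay compound 3 gives 202000 nM.

Compound 1 therefore stands only at a limit; of the three values shown, one other is a limit as well. All three compounds share the same core and differ only in the ring carried on the amide nitrogen. Compound 4 is `Cc1ccc(NC(=O)CSc2snnc2-c2ccc(Br)cc2Br)c(Br)c1`, and it differs from compound 1 as follows: 2-bromo-4-methylphenyl in place of 2,6-dimethylphenyl on an amide-type nitrogen. The steps already measured give little guidance: a step that the two limits leave unreadable from compound 1 to compound 2, a step that the limit leaves unreadable from compound 1 to compound 3 and an at least 1.1-fold lower number from compound 2 to compound 3 (0.07 log units; that floor lies within the scatter), so none of them shows a change beyond the scatter, and every variation of this ring so far has left the cytotoxicity near the top of the measured range. For compound 4, the step that the limit leaves unreadable from compound 1 to compound 4 is expected to stay within the scatter. Compound 4 is therefore estimated to give 200000 nM in this assay, with a range from 100000 nM to 400000 nM, and the assay may well report only a limit.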

Compound 4, half-maximal cytotoxic concentration: > 216000 nM
Compound 4 was reported as a limit; the forecaster's own chance of this, stated with the estimate: 60%; middle value at least 1.0-fold (0.03 log units) from the limit.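

None of the earlier rings on the amide-type nitrogen carried bromine, and in this assay compound 4, with its 2-bromo-4-methylphenyl ring, gives > 216000 nM, which is a limit of the assay. Among these compounds, the one step that can be read is an at least 1.0-fold higher number from compound 3 to compound 4 (0.02 log units; that floor lies within the scatter); it is only a floor, so this change gives no sign of greater toxicity, but its true size remains unknown. The steps from compound 1 and from compound 2 to compound 4 cannot be read, because each joins two limits, among them: the limit of > 216000 nM in this assay, at which 1 of the 4 values shown sits.

Every group shown on this nitrogen is a substituted phenyl ring, so it remains open whether a phenyl ring carrying an amine or a carboxylic acid, or a longer chain in place of the ring, would bring the number down. On these data alone, the true values of compound 1, compound 2 and compound 4 also remain open.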